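A few compounds are considered here, and "the series" means these few. Any claim that something is new, unique, unknown or untested is made for them only; others in the source may bear on it.

Compounds measured so far:

Compound 1, `COc1cc2cc(Oc3ccc(NC(=O)Nc4ccccc4)cc3)c(C)nc2cc1OC`, gives 38.8% in a functional assay on RPMI-8226 cells (Homo sapiens) for inhibition, read by sulforhodamine B assay, with a stated time of 48 h, tested at 10 uM; on this read-out higher numbers stand for a weaker effect at the one concentration tested and lower numbers for a stronger effect.
Compound 2, `COc1cc2cc(Oc3ccc(NC(=O)Nc4ccc(C)cc4)cc3)c(C)nc2cc1OC`, gives 101% in this assay.

Compound 1 stands lowest of the two numbers; its nearest neighbour is compound 2, which differs from it by a number 62.2 percentage points higher from compound 1 to compound 2 (beyond the scatter), a step brought about by methyl in place of hydrogen on an aromatic carbon. Compound 3, `COc1cc2cc(Oc3ccc(NC(=O)Nc4ccc(C(F)(F)F)cc4)cc3)c(C)nc2cc1OC`, has not yet been measured. It differs from compound 1 by trifluoromethyl in place of hydrogen on an aromatic carbon. Within the data shown here, the one measured step that bears on this change is the one from compound 1 to compound 2, where a group entered at the same place and the number rose by a number 62.2 percentage points higher from compound 1 to compound 2 (beyond the scatter). Because the measured step is a number 62.2 percentage points higher from compound 1 to compound 2 (beyond the scatter), the step from compound 1 to compound 3 is expected to go the same way, and the expected size is a number 46.2 percentage points higher from compound 1 to compound 3 (beyond the scatter). Compound 3 is therefore estimated to give 85% in this assay, with a range from 55% to 105%.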

Compound 3, a percentage reported as activity, at one concentration (the size of the read-out at that concentration, not a potency): 52.7%
For compound 3 the middle estimate is 32.3 percentage points above the measured one; the whole stated range lies above it.
By their numbers in this assay, from the lowest: compound 1; then compound 3; then compound 2.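

Trifluoromethyl on this aromatic carbon, para to a large group, also moves the number up in this assay, with a number 13.9 percentage points higher from compound 1 to compound 3 (beyond the scatter) and thus a weaker effect at the one concentration tested, so both groups shown here do worse than hydrogen. The outcome still depends on which group enters: exchanging methyl for trifluoromethyl gives a number 48.3 percentage points lower from compound 2 to compound 3 (beyond the scatter), which recovers much of the effect, although hydrogen remains the best of the three at this position. Nothing available here explains why these two groups differ so widely.

On these data alone, whether a chlorine atom, a methoxy group or an amine on this same carbon would come closer to hydrogen or to methyl remains open. As far as these compounds go, it is also open whether the order of these three compounds would hold at other concentrations.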